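The source may report more compounds than this note shows. Statements on the series, on what has been measured and on what is new or still open speak of the compounds shown alone.

Measured so far:
compound 1 `O=C(Nc1cc(Sc2ncnc3nc[nH]c23)c(O)c2ccccc12)c1ccc([N+](=O)[O-])cc1` — > 100000 nM
compound 2 `O=C(Nc1cc(Sc2ncn[nH]2)c(O)c2ccccc12)c1cccc([N+](=O)[O-])c1` — 70200 nM
compound 3 `O=C(Nc1cc(Sc2nncs2)c(O)c2ccccc12)c1ccc(Cl)cc1` — > 100000 nM

Among the measured compounds shown here, in a functional assay on HCT-116 cells (Homo sapiens) for antiproliferative activity, read by MTT assay, with a stated time of 48 h (a lower number here means a stronger inhibitor, a higher number a weaker inhibitor), compound 2 gives the only number of the three. The values of compound 1 and compound 3 are limits, not numbers. The remaining two values thus sit at the limit of > 100000 nM in this assay, at which 2 of the 3 values shown sit. For the measured compounds named here, compound 2 is weak on this showing, yet it is the sole compound with a measurable read-out.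

Compound 4 `O=C(Nc1cc(Sc2ncn[nH]2)c(O)c2ccccc12)c1ccc([N+](=O)[O-])cc1` is not yet measured. It differs from compound 2 in 4-nitrophenyl in place of 3-nitrophenyl on a carbonyl carbon. Going by the values given here, no measured step of this kind is available, so the expected step in this assay is small, if anything toward a weaker value, and may not exceed the scatter: a 1.3-fold higher number from compound 2 to compound 4 (0.11 log units; within the scatter). Compound 4 is expected at 90000 nM, within 40000 nM to 200000 nM, with a fair chance that only a limit is returned.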

Compound 4, half-maximal inhibitory concentration: > 100000 nM
Compound 4 was reported as a limit; the forecaster's own chance of this, stated with the estimate: 45%; middle value at least 1.1-fold (0.04 log units) away from the limit.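

In this assay, among the compounds shown here, 4-nitrophenyl in place of 3-nitrophenyl on a carbonyl carbon is the first single-place change that can be read, and it gives an at least 1.4-fold higher number from compound 2 to compound 4 (0.15 log units; that floor lies within the scatter). Compound 4 is a limit, not a number, and it joins the others there: the limit of > 100000 nM in this assay, at which 3 of the 4 values shown sit. The change is therefore not shown to matter, and the step between the two limits of compound 1 and compound 4 cannot be read.

Going by these compounds, whether an aminophenyl or a carboxyphenyl on that carbonyl carbon would give a measurable value remains open. On these data alone, the true size of the nitrophenyl step also remains open.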